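The source may hold more compounds than are shown below. What is called first, only, known or untested is meant among the compounds shown, and "the series" means these compounds.

Working notes on the series, read in a functional assay on MT4 cells (Homo sapiens) for cytotoxicity; on this read-out higher numbers stand for weaker inhibition and lower numbers for stronger inhibition. Compound 1 `N#Cc1c(N)cccc1Sc1ccccc1` gives 168000 nM, compound 3 `N#Cc1c(N)cccc1Sc1ccc(Cl)cc1` gives 113000 nM, and compound 2 `N#Cc1c(N)cccc1Sc1cccc(Cl)c1` gives 53000 nM, the lowest of the three numbers. Still unmeasured is compound 4 `N#Cc1cccc(Sc2cccc(N)c2C#N)c1`, which has cyano in place of chloro on an aromatic carbon, meta to a large group: cyano in place of chloro on an aromatic carbon.

Two chloro steps bear on this change. One is modest, a 3.2-fold lower number from compound 1 to compound 2 (0.50 log units; beyond the scatter), and leads to compound 2 itself. The other, a 1.5-fold lower number from compound 1 to compound 3 (0.17 log units; within the scatter), stays within the scatter. For the measured compounds named here, no measured compound carries cyano on this ring, so the data give no direct reading for that group. Removing the chloro of compound 2 undoes a step of only modest size, a 3.2-fold lower number from compound 1 to compound 2 (0.50 log units; beyond the scatter), so a modest move to a higher number is expected in this assay. The expected step is a 1.7-fold higher number from compound 2 to compound 4 (0.23 log units; within the scatter). For compound 4 the estimated value is 90000 nM, with an expected range of 35000 nM to 200000 nM.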

Compound 4, half-maximal inhibitory concentration: 80000 nM
Compound 4: middle estimate off by 1.1-fold (0.05 log units), on the high side; the range from low to high includes it.
By their numbers in this assay, from the lowest: compounds 2, 4, 3 and 1 (each within the scatter of the next, the first and the last beyond it).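

In this assay, cyano and chloro at this place on the ring, meta to a large group, cannot be told apart (a 1.5-fold higher number from compound 2 to compound 4 (0.18 log units; within the scatter)). Compared with hydrogen, cyano still gives a modest change that lies beyond the scatter (a 2.1-fold lower number from compound 1 to compound 4 (0.32 log units; beyond the scatter)), so a second group now joins chloro in moving the number at this place, and in the same direction. No measurement on these compounds accounts for the closeness of cyano and chloro here.

The compounds shown leave open whether a different kind of group at this place, such as an amine, a methoxy or a carboxylic acid, would keep the number in this range. They also leave open whether cyano at the chloro position of compound 3 would read like that chloro or like compound 4.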